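From 2,4-dichlorophenyl to 3-chlorobenzyl on an amide-type nitrogen

The compounds below may be only part of what the source reports. "The series", "measured", "known", "first", "only" and "open" are said of these compounds alone.

- compound 1 `CCN1CCc2c(sc(NC(=O)NCC3CCCO3)c2C(N)=O)C1`: > 25000 nM (a limit of the assay)
- compound 2 `CCN1CCc2c(sc(NC(=O)Nc3ccc(Cl)cc3Cl)c2C(N)=O)C1`: 11500 nM (a measured number)

Among the measured compounds shown here, in a functional assay (strain AB) with Danio rerio as the target, read by microscopy, with a stated time of 1 h (a higher number here means that more compound is needed for the effect, a lower number that less compound is needed), compound 2 gives 11500 nM (the only true number so far). Compound 1 gives > 25000 nM (a limit of the assay, not a number). Compound 3 `CCN1CCc2c(sc(NC(=O)NCc3cccc(Cl)c3)c2C(N)=O)C1` carries 3-chlorobenzyl in place of 2,4-dichlorophenyl on an amide-type nitrogen. For the measured compounds named here, one measured step bears on this change: the swap of (oxolan-2-yl)methyl for 2,4-dichlorophenyl at that same place gave an at least 2.1-fold lower number from compound 1 to compound 2 (0.33 log units; beyond the scatter) as its result. Compound 3 keeps a six-membered aromatic ring of carbon only, as compound 2 does. With so little to go on, only a small step is expected: a 1.3-fold higher number from compound 2 to compound 3 (0.12 log units; within the scatter) in this assay (toward a higher number, but none beyond the usual scatter). The estimate for compound 3 is 15000 nM (expected range 7000 nM to 25000 nM).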

Compound 3, half-maximal effective concentration: > 25000 nM
Compound 3 ended at the assay's limit; the forecaster's own chance of this, stated with the estimate: 35%; middle value at least 1.6-fold (0.22 log units) away from the limit.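

In this assay, 3-chlorobenzyl in place of 2,4-dichlorophenyl on the amide-type nitrogen gives an at least 2.1-fold higher number from compound 2 to compound 3 (0.33 log units; beyond the scatter). Compound 3 gives > 25000 nM, which is a limit of the assay and not a number. Both groups have one six-membered aromatic ring of carbon only and the same count of heavy atoms, so the earlier suggestion that such a ring favours a lower number now needs narrowing: having the ring at this place is not enough on its own.

From the compounds shown here alone, the step between compound 1 and compound 3 cannot be read, because both values are limits: the limit of > 25000 nM in this assay, at which 2 of the 3 values shown sit. Still open is whether the chain carbon or the chlorine pattern matters more, since both change together here; a 3-chlorophenyl group on this nitrogen would separate the two.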